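This account rests on a few compounds, and the source may have more. Where it says the series, first, only, none or still open, it means among the compounds named here.

Compound 1 `COc1cc(OC)c2c(c1)C(C(O)c1ccc(O)cc1)OC2=O`, in an ADME assay on RAW264.7 cells (Mus musculus) for cytotoxicity, read by MTT assay, with a stated time of 24 h, in the absence of a further agent (on this read-out higher numbers stand for weaker inhibition and lower numbers for stronger inhibition), compound 1 gives > 40000 nM, a limit of the assay.
Compound 2 `CCOc1ccc(C(O)C2OC(=O)c3c(OC)cc(OC)cc32)cc1`, in this assay compound 2 gives > 40000 nM, also a limit.

Compound 1 thus stands only at a limit, as does compound 2; the step that the two limits leave unreadable from compound 1 to compound 2 cannot be read, since both values sit at the limit of > 40000 nM in this assay, at which 2 of the 2 values shown sit. Compound 3 `COc1cc(OC)c2c(c1)C(C(O)c1ccc(OCc3ccccc3)cc1)OC2=O` differs from compound 1 by benzyl in place of hydrogen on an oxygen on an aromatic ring. Among the measured compounds shown here, no measured step bears on this change beyond the unreadable one. Compound 3 is therefore expected to remain at the limit, a step of a number no higher from compound 1 to compound 3 (the limit leaves the size open) of no readable size, with an estimate of 40000 nM ranging from 20000 nM to 80000 nM.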

Compound 3, half-maximal inhibitory concentration: > 40000 nM
Compound 3 gave a limit, no number; the forecaster's own chance of this, stated with the estimate: 80%; the middle value sits exactly at the limit.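

No new step can be read among compound 1, compound 2 and compound 3 in this assay, as all three stand at a limit: the limit of > 40000 nM in this assay, at which 3 of the 3 values shown sit. The compounds shown leave open whether ethyl or benzyl in place of hydrogen on an oxygen on an aromatic ring changes the read-out at all.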